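Amide-free carboxylic acid series: the nitrogen substituent step

The compounds below may be only part of what the source reports. "The series", "measured", "known", "first", "only" and "open" are said of these compounds alone.

Measured so far in an assay on HEK-293T cells for antagonist activity at vitamin D3 receptor (Homo sapiens), read by a luciferase reporter, with a stated time of 24 h; on this read-out lower numbers stand for stronger inhibition and higher numbers for weaker inhibition:
compound 1 `CC(C)c1onc(-c2c(Cl)cccc2Cl)c1COc1ccc(-c2nc3ccc(C(=O)O)cc3n2C)cc1` gives 7150 nM
compound 2 `CCCn1c(-c2ccc(OCc3c(-c4c(Cl)cccc4Cl)noc3C(C)C)cc2)nc2ccc(C(=O)O)cc21` gives 1400 nM
compound 3 `CC(C)c1onc(-c2c(Cl)cccc2Cl)c1COc1ccc(-c2nc3ccc(C(=O)O)cc3n2CC2CCCCC2)c(Cl)c1` gives 160 nM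

Compound 2 stands second highest of the three numbers; compound 1 sits above it and compound 3 far below it. Among the compounds with values here, the one single-place step in the set is a 5.1-fold lower number from compound 1 to compound 2 (0.71 log units; beyond the scatter), so extending the group on the aromatic nitrogen of the shared core has already moved the number down by a modest amount, well beyond the scatter. Within the data shown here, compound 3 carries both a different group on that nitrogen and an extra chlorine, so no single step connects it to compound 2; its two values with compound 2 merely show that a compound with a larger nitrogen substituent can read much lower in this assay.

Compound 4 `CC(C)c1onc(-c2c(Cl)cccc2Cl)c1COc1ccc(-c2nc3ccc(C(=O)O)cc3n2C2CCCC2)cc1` is the next compound to be tested, and differs from compound 2 by cyclopentyl in place of propyl on an aromatic nitrogen. The step from compound 1 to compound 2 is the only one that bears directly on this change, and it points downward; the pair of compound 2 and compound 3 points the same way without being a clean step. A further drop of moderate size, beyond the scatter, is therefore expected, as a 2.8-fold lower number from compound 2 to compound 4 (0.45 log units; beyond the scatter). Compound 4 is estimated at 500 nM, with a range from 150 nM to 1600 nM.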

Compound 4, half-maximal inhibitory concentration: 929 nM
Compound 4: middle estimate off by 1.9-fold (0.27 log units), on the low side; measured number inside the range.
By their numbers in this assay, from the lowest: compound 3; then compounds 4 and 2 (each within the scatter of the next); then compound 1.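

In the series as read by this assay the exchange of propyl for cyclopentyl on the aromatic nitrogen gives a 1.5-fold lower number from compound 2 to compound 4 (0.18 log units; within the scatter) and so does not separate the two groups, although cyclopentyl brings a five-membered non-aromatic ring and 5 heavy atoms against 3. Set against the methyl group of compound 1, cyclopentyl gives a 7.7-fold lower number from compound 1 to compound 4 (0.89 log units; beyond the scatter) and this step, like the one to propyl, lies beyond the scatter, so among the three groups on this nitrogen in otherwise identical compounds only methyl stands apart, while propyl and cyclopentyl cannot be told apart. No supporting measurement is available to explain this pattern.

Compound 3 differs from these compounds in two places, its nitrogen group and an added chlorine, so its value of 160 nM cannot be assigned to either change alone. Still open, as far as these compounds go, is how this position responds to a longer chain such as butyl, to a branched group such as tert-butyl, or to a six-membered ring such as cyclohexyl placed directly on the nitrogen, and whether the chlorine contributes anything when present alone on a compound with a propyl or cyclopentyl group.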